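Series notes: from compound 2 to compound 3

This account rests on a few compounds, and the source may have more. Where it says the series, first, only, none or still open, it means among the compounds named here.

Measured in a functional assay on HCT-116 cells (Homo sapiens) for inhibition, read by colorimetric assay, with a stated time of 3 days; on this read-out lower numbers stand for stronger inhibition and higher numbers for weaker inhibition:
- compound 1 `O=C(CCCCCCNC(=O)C(O)(O)C(F)(F)F)Nc1ccccc1`: 9140 nM
- compound 2 `COc1cccc(NC(=O)CCCCCCNC(=O)C(O)(O)C(F)(F)F)c1`: 6110 nM

For the measured compounds named here, only two values are available so far. Compound 2 at 6110 nM lies within the scatter of compound 1 at 9140 nM, so the two cannot be ranked.

The next compound is compound 3 `O=C(CCCCCCNC(=O)C(O)(O)C(F)(F)F)Nc1nc2ccccc2s1`, which differs from compound 2 as follows: 1,3-benzothiazol-2-yl in place of 3-methoxyphenyl on an amide-type nitrogen. In words, this is 1,3-benzothiazol-2-yl in place of 3-methoxyphenyl on an amide-type nitrogen.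

Going by the values given here, one measured step bears on this change, and only in part. The step of a 1.5-fold lower number from compound 1 to compound 2 (0.17 log units; within the scatter) comes from methoxy in place of hydrogen on an aromatic carbon, and it lies within the scatter. Among the compounds with values here, no measured step replaces the whole group on the amide-type nitrogen, so the data give no firm direction for compound 3. Within the data shown here, with the one measured change in this group being that small, no shift beyond the scatter is expected in this assay. The estimated step is a 1.2-fold lower number from compound 2 to compound 3 (0.09 log units; within the scatter). On these data alone, the range is kept wide because this replacement is untested. For compound 3 the estimated value is 5000 nM, with an expected range of 1800 nM to 14000 nM.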

Compound 3, half-maximal inhibitory concentration: 2370 nM
Compound 3: middle estimate off by 2.1-fold (0.32 log units), on the high side; the range from low to high includes it.
By their numbers in this assay, from the lowest: compound 3; then compounds 2 and 1 (each within the scatter of the next).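

In this assay, for the compounds shown here, the group on the amide-type nitrogen is the first place where a change moves the number beyond the scatter: 1,3-benzothiazol-2-yl in place of 3-methoxyphenyl gives a 2.6-fold lower number from compound 2 to compound 3 (0.41 log units; beyond the scatter), and the same group in place of phenyl gives a 3.9-fold lower number from compound 1 to compound 3 (0.59 log units; beyond the scatter). Both steps are modest, but they show that this position responds to replacing the whole group, whereas methoxy in place of hydrogen on an aromatic carbon, with a 1.5-fold lower number from compound 1 to compound 2 (0.17 log units; within the scatter), stayed within the scatter. No measurement available here accounts for the lower numbers seen with 1,3-benzothiazol-2-yl.

On these data alone, it remains open whether a 1,3-thiazol-2-yl or a 1,3-benzoxazol-2-yl group on the same amide-type nitrogen would give a similar step, and so which part of the entering group goes with the lower number. Also open, as far as these compounds go, is whether the step seen with 1,3-benzothiazol-2-yl carries over to a longer chain in the core of compound 1.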